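Cytotoxicity notes: iodo for fluoro on the anilide

The source may report more compounds than this note shows. Statements on the series, on what has been measured and on what is new or still open speak of the compounds shown alone.

Measured so far:
compound 1, `COc1ccc(C(=O)Nc2ccc(Cl)cc2F)c(OC)c1`: 13600 nM
compound 2, `COc1ccc(C(=O)Nc2ccc(F)cc2F)c(OCc2ccc(F)cc2F)c1`: > 40000 nM
compound 3, `O=C(Nc1ccc(I)cc1F)c1ccccc1`: > 40000 nM

In an ADME assay on RAW264.7 cells (Mus musculus) for cytotoxicity, read by MTT assay, with a stated time of 24 h (a lower number here means that less compound is tolerated, a higher number that more compound is tolerated), compound 1 gives 13600 nM. Compound 2 reaches only a limit of the assay, > 40000 nM, and no number. Compound 3 likewise stops at a limit, > 40000 nM. Compound 2 therefore stands at the limit of > 40000 nM in this assay, at which 2 of the 3 values shown sit.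

Compound 4, `COc1ccc(C(=O)Nc2ccc(I)cc2F)c(OCc2ccc(F)cc2F)c1`, differs from compound 2 by iodo in place of fluoro on an aromatic carbon. Within the data shown here, no step between measured compounds covers this change. Compound 3 also carries the iodo group on its anilide and reports only a limit. Compound 4 is therefore expected to show no step beyond the scatter in this assay. Compound 4 is estimated at 40000 nM, within 20000 nM to 80000 nM. The expected step is a number no higher from compound 2 to compound 4 (the limit leaves the size open).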

Compound 4, half-maximal cytotoxic concentration: 36800 nM
Compound 4: middle estimate off by 1.1-fold (0.04 log units), on the high side; the range from low to high includes it.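

In this assay, the change from 2,4-difluorophenyl to 2-fluoro-4-iodophenyl gives an at least 1.0-fold lower number from compound 2 to compound 4 (0.03 log units; that floor lies within the scatter). With iodo on this aromatic carbon, compound 4 gives a number, 36800 nM, which compound 3, also an iodo anilide, did not supply. Compound 2 remains at a limit, so the true size of the step cannot be read: the limit of > 40000 nM in this assay, at which 2 of the 4 values shown sit.

Going by these compounds, whether iodo and fluoro differ at this position beyond the scatter stays open. Also open, on these data alone, is how an amine or a carboxylic acid on this aromatic carbon would read in this assay.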